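A few compounds are considered here, and "the series" means these few. Any claim that something is new, unique, unknown or untested is made for them only; others in the source may bear on it.

The measured compounds so far:

Compound 1 `COc1ccc(/C=N/NC(=S)NC(C)(C)[C@H]2CC=C(C)CC2)cc1` gives 37700 nM in a functional assay on MCF7 cells (Homo sapiens) for inhibition, read by sulforhodamine B assay, with a stated time of 48 h; a higher number here means a weaker inhibitor of growth, a lower number a stronger inhibitor of growth.
Compound 2 `CC1=CC[C@H](C(C)(C)NC(=S)N/N=C/c2ccccc2O)CC1` gives 17500 nM in this assay.
Compound 3 `CC1=CC[C@H](C(C)(C)NC(=S)N/N=C/c2ccc(F)cc2)CC1` gives only > 100000 nM in this assay, which is a limit of the assay and not a number.

Compound 3 therefore stands at the weak end of the three: the steps of an at least 2.6-fold higher number from compound 1 to compound 3 (0.42 log units; beyond the scatter) and an at least 5.7-fold higher number from compound 2 to compound 3 (0.75 log units; beyond the scatter) both run toward the limit, and the limit of > 100000 nM in this assay, at which 1 of the 3 values shown sits, is where compound 3 alone sits among the three values. In the other direction the step of a 2.2-fold lower number from compound 1 to compound 2 (0.33 log units; beyond the scatter) shows a modest gain.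

Compound 4 `CC1=CC[C@H](C(C)(C)NC(=S)N/N=C/c2ccco2)CC1` differs from compound 3 by furan-2-yl in place of 4-fluorophenyl on a carbon with a double bond to nitrogen. Within the data shown here, the steps that bear on this are those in which the aryl group on the carbon double-bonded to nitrogen was exchanged, an at least 2.6-fold higher number from compound 1 to compound 3 (0.42 log units; beyond the scatter) and an at least 5.7-fold higher number from compound 2 to compound 3 (0.75 log units; beyond the scatter), both modest and both moving away from the limit when read back toward compounds 1 and 2. The furan-2-yl group brings a hydrogen-bond acceptor, as methoxy in compound 1 does, so a modest return from the limit toward the region of compound 1 in this assay is expected, though a limit again remains possible.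

Compound 4 is estimated at 50000 nM, with a range of 15000 nM to 200000 nM, the expected step being an at least 2.0-fold lower number from compound 3 to compound 4 (0.30 log units; that floor lies within the scatter).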

Compound 4, concentration for total growth inhibition: 53700 nM
Beside the measured number, compound 4's estimate is 1.1-fold (0.03 log units) below it, and the stated range covers the measured number.
By their numbers in this assay, from the lowest: compound 2; then compounds 1 and 4 (each within the scatter of the next). At a limit, above all of these: compound 3.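

Compound 3 carries the only limit in the set, which is a limit of the assay and not a number: the limit of > 100000 nM in this assay, at which 1 of the 4 values shown sits.

Exchanging its 4-fluorophenyl for furan-2-yl gives an at least 1.8-fold lower number from compound 3 to compound 4 (0.27 log units; that floor lies within the scatter), so a measured number returns in this assay, although the true size of this step cannot be read. Furan-2-yl also stands within the scatter of 4-methoxyphenyl, a 1.4-fold higher number from compound 1 to compound 4 (0.15 log units; within the scatter), while 2-hydroxyphenyl keeps a modest lead over it, a 3.1-fold higher number from compound 2 to compound 4 (0.49 log units; beyond the scatter), so at this place on a carbon with a double bond to nitrogen a six-membered aromatic ring of carbon only is not needed for a value in the range of compound 1.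

The compounds shown leave open whether the return with furan-2-yl comes from its ring oxygen or from the five-membered ring itself, and a thiophene or a pyridine ring at this place would be the natural groups to tell these apart. They also leave open how far any group here could go beyond compound 2 in this assay, and whether a carboxylic acid or an amine on the aromatic ring would be tolerated.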